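The source may hold more compounds than are shown below. What is called first, only, known or untested is meant among the compounds shown, and "the series" means these compounds.

Of the compounds shown here, three built on one shared core have so far been read in a functional assay on LOX IMVI cells (Homo sapiens) for cytotoxicity, read by sulforhodamine B assay, with a stated time of 48 h, tested at 0.01 uM; a higher number here means a weaker effect of the compound at the concentration tested, a lower number a stronger effect. Compound 1 `COc1cc(-c2cc(/C=C/C(=O)c3ccc(N)cc3)[nH]n2)cc(OC)c1OC` gives 98% there. Compound 2 `COc1cc(-c2cc(/C=C/C(=O)c3ccc(Cl)c(Cl)c3)[nH]n2)cc(OC)c1OC` gives 96% in this assay, and compound 3 `COc1ccc(C(=O)/C=C/c2cc(-c3cc(OC)c(OC)c(OC)c3)n[nH]2)cc1OC` gives 92% in this assay. The three numbers sit close together: a number 2 percentage points lower from compound 1 to compound 2 (within the scatter), a number 6 percentage points lower from compound 1 to compound 3 (within the scatter), and a number 4 percentage points lower from compound 2 to compound 3 (within the scatter). Compound 3 thus holds the lowest of the three numbers, but its gaps to compound 2 and to compound 1 both lie within the scatter, so no order among the three can be read from them.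

The next compound, compound 4 `COc1ccc(C(=O)/C=C/c2cc(-c3cc(OC)c(OC)c(OC)c3)n[nH]2)cc1`, differs from compound 3 in a single place.
hydrogen in place of methoxy on an aromatic carbon
For the measured compounds named here, none of the measured steps touches this part of the molecule: each of them exchanges the whole aryl group on the carbonyl carbon, and each stayed within the scatter. Going by the values given here, the measured steps therefore give no sign that this region moves the read-out of this assay, and they give no step of the kind now made.

On that footing compound 4 is expected to give about 93% in this assay, with a range from 84% to 100%. The expected step is a number 1 percentage points higher from compound 3 to compound 4 (within the scatter), that is, none beyond the scatter.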

Compound 4, a percentage reported as activity, at one concentration (the size of the read-out at that concentration, not a potency): 95%
Compound 4: the middle estimate sits 2 percentage points below what was measured; the measured number falls inside the stated range.
By their numbers in this assay, from the lowest: compounds 3, 4, 2 and 1 (each within the scatter of the next).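

For the compounds shown here, the hydrogen in place of methoxy is the first measured change confined to a single substituent on the aryl group on the carbonyl carbon, rather than an exchange of the whole group, and in this assay it gives a number 3 percentage points higher from compound 3 to compound 4 (within the scatter) at this position, ortho to a methoxy group and meta to a large group. Going by these compounds alone, the 4-methoxyphenyl group of compound 4 also leaves the read-out within the scatter of the other two aryl groups, with a number 1 percentage points lower from compound 2 to compound 4 (within the scatter) on exchange for 3,4-dichlorophenyl and a number 3 percentage points lower from compound 1 to compound 4 (within the scatter) on exchange of amino for methoxy, so no step among the four compounds separates one from another at this single concentration. No measurement shown here offers an explanation for these numbers.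

From the compounds shown here alone, whether a hydroxy group, a fluorine atom or an amine at this same position would produce a step beyond the scatter remains open. So does whether the same methoxy-to-hydrogen exchange would leave the read-out unchanged at a higher concentration, where the numbers might spread further apart.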